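Fluoro for Hydrogen on the Anilide Ring of Compound 1

The source may report more compounds than this note shows. Statements on the series, on what has been measured and on what is new or still open speak of the compounds shown alone.

In a functional assay on MGC-803 cells (Homo sapiens) for inhibition, read by MTT assay, with a stated time of 72 h (on this read-out lower numbers stand for stronger inhibition and higher numbers for weaker inhibition), compound 1 `O=C(Nc1ccccc1)C1CCN(C/C=C/c2ccccc2)CC1` gives 57900 nM, the second highest of three numbers. Its nearest neighbour is compound 3 `COc1ccccc1NC(=O)C1CCN(C/C=C/c2ccccc2)CC1`, with 71200 nM; the step from compound 1 to compound 3 is a 1.2-fold higher number from compound 1 to compound 3 (0.09 log units; within the scatter). Furthest away is compound 2 `CCCc1ccc(NC(=O)C2CCN(C/C=C/c3ccccc3)CC2)cc1`, with 5210 nM; the step from compound 1 to compound 2 is an 11-fold lower number from compound 1 to compound 2 (1.05 log units; beyond the scatter), a large one. Compound 4 `O=C(Nc1cccc(F)c1)C1CCN(C/C=C/c2ccccc2)CC1` differs from compound 1 by fluoro in place of hydrogen on an aromatic carbon.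

Among the measured compounds shown here, two measured steps bear on this change, both substitutions on the same aromatic ring. A methoxy gave a 1.2-fold higher number from compound 1 to compound 3 (0.09 log units; within the scatter), while a propyl gave an 11-fold lower number from compound 1 to compound 2 (1.05 log units; beyond the scatter). No fluoro and no group meta to a large group has been measured, so the direction of this step is not settled. For the measured compounds named here, a single fluorine is the smallest entering group here, and the one group of comparable size, methoxy, produced nothing beyond the scatter. Compound 4 is therefore expected to show a 1.4-fold lower number from compound 1 to compound 4 (0.16 log units; within the scatter) in this assay, a step likely within the scatter or at most modest, estimated at 40000 nM with a range from 15000 nM to 100000 nM.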

Compound 4, half-maximal inhibitory concentration: 23300 nM
For compound 4 the middle estimate is 1.7-fold (0.23 log units) above the measured one; the range from low to high includes it.
By their numbers in this assay, from the lowest: compound 2; then compound 4; then compounds 1 and 3 (each within the scatter of the next).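

In this assay, the step of a 2.5-fold lower number from compound 1 to compound 4 (0.40 log units; beyond the scatter) shows that a single fluoro, meta to a large group, can move the number beyond the scatter, something the methoxy of compound 3 did not do. The choice of substituted phenyl on the amide nitrogen also matters at this level, with a 3.1-fold lower number from compound 3 to compound 4 (0.49 log units; beyond the scatter) on one side and a 4.5-fold higher number from compound 2 to compound 4 (0.65 log units; beyond the scatter) on the other, so the 3-fluorophenyl compound sits between the 2-methoxyphenyl and 4-propylphenyl compounds. Nothing available explains why this change has the effect it has.

As far as these compounds go, it remains open whether the effect belongs to fluoro itself or to the place it occupies, and whether chloro, methyl or an amine on the same carbon would do the same. The compounds shown also do not tell whether fluoro and propyl together on one ring would add up, or whether a longer chain would go further than propyl.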